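This account rests on a few compounds, and the source may have more. Where it says the series, first, only, none or still open, it means among the compounds named here.

Measured compounds:
compound 1 `CC(C)c1cnc(Nc2cccc(F)c2)nc1NCCCNC(=O)C1CCC1` — > 1000 nM
compound 2 `O=C(NCCCNc1nc(Nc2cnn(C3CCOCC3)c2)ncc1C1CC1)C1CCC1` — 2 nM

In an assay on isolated protein for inhibition of serine/threonine-protein kinase TBK1 (Homo sapiens) (on this read-out lower numbers stand for stronger inhibition and higher numbers for weaker inhibition), compound 1 gives > 1000 nM, which is a limit of the assay and not a number. Compound 1 therefore stands at the limit of > 1000 nM in this assay, at which 1 of the 2 values shown sits, and its place among the numbers shown is known only as that limit. Compound 2 gives 2 nM in this assay; it differs from compound 1 in more than one place, so its value shows only that strong inhibition is reachable in this series.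

Compound 3 `O=C(NCCCNc1nc(Nc2cccc(F)c2)ncc1C1CC1)C1CCC1` is not yet measured. Compared with compound 1 it carries cyclopropyl in place of isopropyl on an aromatic carbon. Within the data shown here, no measured pair with this change exists here. The size of the step in this assay is therefore open. Compound 1 stands at a limit. For compound 3 any outcome up to a clear gain is possible. Compound 3 is expected to give 300 nM, within 30 nM to 3000 nM. The expected at least 3.3-fold lower number from compound 1 to compound 3 (0.52 log units; beyond the scatter) would be a gain beyond the scatter.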

Compound 3, half-maximal inhibitory concentration: 8 nM
The estimate for compound 3 lay 38-fold (1.57 log units) above the measured number, and the stated range ends above it.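

In this assay compound 1 gives > 1000 nM, which is a limit of the assay and not a number. Cyclopropyl in place of isopropyl on this aromatic carbon keeps the count of three carbons but closes them into a ring, and this single change gives an at least 120-fold lower number from compound 1 to compound 3 (2.09 log units; beyond the scatter), so the position responds strongly even though no heavy atom is added. The step can be read only as a minimum, not as an exact size, because of where compound 1 stands: the limit of > 1000 nM in this assay, at which 1 of the 3 values shown sits.

Among these compounds, with only this one pair, it remains open whether a ring is needed here or whether another small group, such as methyl, ethyl or cyclobutyl, would serve as well. From the compounds shown here alone, it is also open whether the change would have the same effect without the (3-fluorophenyl)amino group, for example in the setting of compound 2.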